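The source may hold more compounds than are shown below. What is called first, only, known or untested is meant among the compounds shown, and "the series" means these compounds.

Measured in a functional assay on K562 cells (Homo sapiens) for cytotoxicity, read by flow cytometry, with a stated time of 72 h; on this read-out higher numbers stand for weaker inhibition and lower numbers for stronger inhibition:

Compound 1 `Cc1ccc(S(=O)(=O)Cc2nc(Nc3cccc(C(F)(F)F)c3)c3ccccc3n2)cc1` gives > 25000 nM
Compound 2 `CC(C)=Cc1nc(Nc2cccc(C(F)(F)F)c2)c2cc([N+](=O)[O-])ccc2n1` gives > 125000 nM
Compound 3 `Cc1ccc(S(=O)(=O)Cc2nc(Nc3ccccc3)c3cc([N+](=O)[O-])ccc3n2)cc1` gives > 125000 nM

All three entries are limits of the assay, not numbers, so the three compounds cannot be ranked against one another. Compound 3 stands at > 125000 nM, which is a limit. Across the set, the record shows (the limit of > 125000 nM in this assay, at which 2 of the 3 values shown sit), together with the limit of > 25000 nM in this assay, at which 1 of the 3 values shown sits.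

The step to follow leads to compound 4 `Cc1ccc(S(=O)(=O)Cc2nc(Nc3cccc(C(F)(F)F)c3)c3cc([N+](=O)[O-])ccc3n2)cc1`, which has not yet been measured. The change is trifluoromethyl in place of hydrogen on an aromatic carbon, with trifluoromethyl in place of hydrogen on an aromatic carbon, so that the phenyl becomes 3-(trifluoromethyl)phenyl.

For the measured compounds named here, no measured pair shows what this change does on its own, so any expectation rests on weak ground. Compound 2 already carries the 3-(trifluoromethyl)phenyl group, and it reads > 125000 nM, again a limit. Compound 1 carries the same group, and it reads > 25000 nM, also a limit. No step beyond the usual scatter is therefore expected in this assay, in either direction, and another limit is the likeliest result. The estimated change is a number no higher from compound 3 to compound 4 (the limit leaves the size open), and it is only an expectation. For compound 4 the estimated value is 125000 nM, with an expected range from 40000 nM to 250000 nM.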

Compound 4, half-maximal inhibitory concentration: > 125000 nM
Compound 4 ended at the assay's limit; the forecaster's own chance of this, stated with the estimate: 80%; the middle value lies on the limit itself.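

Compound 4 gives > 125000 nM, which is a limit of the assay and not a number. For the compounds shown here, the entries for compound 1, compound 2 and compound 3 are limits too, so no step to compound 4 can be read. The compounds shown leave open what any of these changes does, including trifluoromethyl in place of hydrogen, and whether any compound on this core gives a true number.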